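The compounds below may be only part of what the source reports. "The series", "measured", "known", "first", "only" and "open" are said of these compounds alone.

Compound 1 `O=C1c2ccccc2S(=O)(=O)N1CCCCCCN1CCN(c2cccc(Cl)c2)CC1` gives 372 nM in an ADME assay on HEK293 cells for displacement of a labelled ligand from 5-hydroxytryptamine receptor 6 (Homo sapiens), read by radioligand binding, with a stated time of 1 h (on this read-out higher numbers stand for weaker inhibition and lower numbers for stronger inhibition), the second highest of the three numbers measured. Compound 2 `O=C1c2ccccc2S(=O)(=O)N1CCCCCCN1CCN(c2ccccc2C(F)(F)F)CC1` gives 1270 nM, and compound 3 `O=C1c2ccccc2S(=O)(=O)N1CCCCCCN1CCN(c2cccc(C(F)(F)F)c2)CC1` gives 52 nM. The measured steps are a 3.4-fold higher number from compound 1 to compound 2 (0.53 log units; beyond the scatter), a 7.2-fold lower number from compound 1 to compound 3 (0.85 log units; beyond the scatter) and a 24-fold lower number from compound 2 to compound 3 (1.39 log units; beyond the scatter); all three change the group on the same ring nitrogen, and each shifts the number beyond the scatter. Compound 4 `O=C1c2ccccc2S(=O)(=O)N1CCCCCCN1CCN(c2ncccn2)CC1` differs from compound 1 by pyrimidin-2-yl in place of 3-chlorophenyl on an amine nitrogen in a ring. Among the measured compounds shown here, no measured step replaces the all-carbon ring with a ring bearing hetero atoms, so the direction rests on the size of the nearby steps only. A higher number is expected, with a 4.0-fold higher number from compound 1 to compound 4 (0.61 log units; beyond the scatter). For compound 4 the estimate in this assay is 1500 nM, between 400 nM and 6000 nM.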

Compound 4, inhibition constant: 104 nM
Compound 4: the middle estimate sits 14-fold (1.16 log units) above what was measured, outside the stated range (below it).
By their numbers in this assay, from the lowest: compounds 3 and 4 (each within the scatter of the next); then compound 1; then compound 2.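

Pyrimidin-2-yl on this ring nitrogen gives a 3.6-fold lower number from compound 1 to compound 4 (0.55 log units; beyond the scatter) and a 12-fold lower number from compound 2 to compound 4 (1.09 log units; beyond the scatter) in this assay and so shows that the group need not be a substituted all-carbon ring. Its comparison with 3-(trifluoromethyl)phenyl gives a 2.0-fold higher number from compound 3 to compound 4 (0.30 log units; within the scatter) and does not separate the two groups. Nothing available explains why this ring with hetero atoms fares so well. Still open, going by these compounds, is whether the gain belongs to the ring nitrogens themselves, which plain phenyl and pyridin-2-yl on the same nitrogen would help to test.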